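Swapping the nitro-bearing ring for a hydroxynaphthalene

This account rests on a few compounds, and the source may have more. Where it says the series, first, only, none or still open, it means among the compounds named here.

Of the compounds shown here, three sharing one core have been measured in a functional assay on Ehrlich cells (Mus musculus) for cytotoxicity, read by trypan blue exclusion, with a stated time of 2 h, tested at 50 ug/mL; on this read-out higher numbers stand for a stronger effect at the one concentration tested and lower numbers for a weaker effect. Compound 1 `N#CC1=C(N)N(c2ccc(S(N)(=O)=O)cc2)C2=C(CCCC2)C1c1ccccc1O` gives 50% in this assay. Compound 2 `COc1ccccc1C1C(C#N)=C(N)N(c2ccc(S(N)(=O)=O)cc2)C2=C1CCCC2` gives 50%, and the step of no change at the digits printed from compound 1 to compound 2 (within the scatter) shows how little the methyl on the oxygen matters here. Compound 3 `N#CC1=C(N)N(c2ccc(S(N)(=O)=O)cc2)C2=C(CCCC2)C1c1ccc([N+](=O)[O-])cc1` gives 10%, the lowest of the three numbers; the steps of a number 40 percentage points lower from compound 1 to compound 3 (beyond the scatter) and a number 40 percentage points lower from compound 2 to compound 3 (beyond the scatter) both show a drop that is large and beyond the scatter, each arising when 4-nitrophenyl takes the place of the earlier ring on the saturated ring carbon.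

Compound 4 `N#CC1=C(N)N(c2ccc(S(N)(=O)=O)cc2)C2=C(CCCC2)C1c1c(O)ccc2ccccc12` has not yet been measured. The change from compound 3 is 2-hydroxynaphthalen-1-yl in place of 4-nitrophenyl on a saturated ring carbon. Both measured steps bear on this change, since both concern the same saturated ring carbon and both reverse in direction when the 4-nitrophenyl leaves. Within the data shown here, the entering group carries a hydroxyl like the one in compound 1, whose value 50% is the best guide. Compound 4 is therefore expected to recover most of the lost activity, with an estimated step of a number 35 percentage points higher from compound 3 to compound 4 (beyond the scatter). The estimate for compound 4 in this assay is 45%, with a range from 25% to 65%.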

Compound 4, a percentage reported as activity, at one concentration (the size of the read-out at that concentration, not a potency): 20%
Compound 4: the middle estimate sits 25 percentage points above what was measured, and the stated range ends above it.
By their numbers in this assay, from the lowest: compounds 3 and 4 (each within the scatter of the next); then compounds 1 and 2 (each within the scatter of the next).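

In this assay a hydroxyl on the group at this saturated ring carbon is not enough to carry the higher numbers: 2-hydroxynaphthalen-1-yl in place of 4-nitrophenyl gives a number 10 percentage points higher from compound 3 to compound 4 (within the scatter), so compound 4, which has a hydroxyl, cannot be told apart from compound 3, which has none. The comparison with the single-ring groups points to the second aromatic ring as the new factor, since the steps are a number 30 percentage points lower from compound 1 to compound 4 (beyond the scatter), where the hydroxyl stays and the second ring enters, and a number 30 percentage points lower from compound 2 to compound 4 (beyond the scatter), where the methoxy group also gives way to a hydroxyl. Among these compounds, these numbers show only that the second ring goes with the lower value, and nothing available here explains the link.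

Still open, on these data alone, is whether the hydroxyl matters at all on the two-ring group, which plain naphthalen-1-yl at this carbon would test directly. Also open, as far as these compounds go, is whether a 2-aminophenyl group, with an amine where compound 1 has its hydroxyl, or a 2-carboxyphenyl group, with a carboxylic acid there, would stand with compound 1 or with compound 3.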